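This account rests on a few compounds, and the source may have more. Where it says the series, first, only, none or still open, it means among the compounds named here.

In an ADME assay on liver for metabolic stability, with Liver microsome (Homo sapiens) as the target, read by LC-MS, using microsomes (on this read-out higher numbers stand for fast clearance and lower numbers for slow clearance), compound 2 `O=C([C@H](O)c1ccccc1)N1CC[C@@H]2C[C@@]21C(=O)NCc1cc(Cl)ccc1-n1cnnn1` gives 43 mL.min-1.g-1 as the higher of two numbers. In a structure that differs from compound 2 in more than one place, compound 1 `CC(C)(C)OC[C@@H](O)C(=O)N1[C@H](C(=O)NCc2cc(Cl)ccc2-n2cnnn2)C[C@@H]2C[C@@H]21` gives 21 mL.min-1.g-1. The gap between these two numbers lies beyond the scatter. Going by the values given here, compound 3 `CC(C)(C)C[C@@H](O)C(=O)N1CC[C@@H]2C[C@@]21C(=O)NCc1cc(Cl)ccc1-n1cnnn1` carries one change from compound 2 (neopentyl in place of phenyl on a saturated chain carbon bound to a carbonyl carbon and an oxygen on a saturated carbon) and no measured step in a single place bears on it. The estimated step (a 1.4-fold lower number from compound 2 to compound 3 (0.16 log units; within the scatter)) is expected to be small, downward and not beyond the scatter. For compound 3 the estimated value is 30 mL.min-1.g-1 within an expected range (14 mL.min-1.g-1 to 62 mL.min-1.g-1).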

Compound 3, intrinsic clearance in microsomes: 27 mL.min-1.g-1
Compound 3: the middle estimate sits 1.1-fold (0.05 log units) above what was measured; the range from low to high includes it.
By their numbers in this assay, from the lowest: compounds 1, 3 and 2 (each within the scatter of the next, the first and the last beyond it).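

In this assay, going by these compounds alone, the first single-place step at this position is a 1.6-fold lower number from compound 2 to compound 3 (0.20 log units; within the scatter) and it stays within the scatter. On a saturated chain carbon bound to a carbonyl carbon and an oxygen on a saturated carbon, phenyl can therefore give way to neopentyl, losing the aromatic ring, with no shift in clearance beyond the scatter. No measured evidence accounts for this step.

Going by these compounds, whether an amine or a carboxylic acid at this place would move clearance beyond the scatter remains open. One step also cannot show how a longer chain would behave here.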